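The source may hold more compounds than are shown below. What is called first, only, known or untested is meant among the compounds shown, and "the series" means these compounds.

Working notes on a cytotoxicity series against a colon carcinoma line.

Compound 1 `O=C(Nc1ccc(Sc2nc3ccccc3s2)cc1)c1cc(Br)cc(Br)c1O` is the reference point. In a functional assay on HT-29 cells (Homo sapiens) for cytotoxicity, read by resazurin assay, with a stated time of 48 h (on this read-out higher numbers stand for an effect only at larger amounts of compound and lower numbers for an effect already at smaller amounts), compound 1 gives 21000 nM. Going by the values given here, the only other measured member is compound 2 `O=S(=O)(Nc1ccc(-c2nc3cc(NS(=O)(=O)c4ccccc4Cl)ccc3o2)cc1)c1ccccc1Cl`, built on a different core; in this assay compound 2 gives 15000 nM. Of the two numbers recorded, compound 1 carries the higher one, but the gap to compound 2 is within the usual scatter of repeat runs, so the two compounds cannot be placed in any order on this read-out and neither can be called the more or less active.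

Compound 3 `O=C(Nc1ccc(Sc2nc3ccccc3s2)cc1)c1cccc(Br)c1O` shares the core of compound 1 and differs from it in one spot: hydrogen in place of bromo on an aromatic carbon. Among the compounds with values here, no measured pair in the set isolates this change, so its effect has to be estimated without a precedent. On balance the step is expected to be small, in the direction of a somewhat higher number, with no change beyond the scatter being an equally plausible outcome: the expected step of a 1.4-fold higher number from compound 1 to compound 3 (0.15 log units; within the scatter) reflects this. Compound 3 is accordingly estimated at 30000 nM, within a range from 10000 nM to 90000 nM.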

Compound 3, half-maximal effective concentration: 9300 nM
Compound 3: middle estimate off by 3.2-fold (0.51 log units), on the high side, and the stated range ends above it.
By their numbers in this assay, from the lowest: compounds 3, 2 and 1 (each within the scatter of the next, the first and the last beyond it).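

In this assay, going by these compounds alone, the change from 3,5-dibromo-2-hydroxyphenyl to 3-bromo-2-hydroxyphenyl gives a 2.3-fold lower number from compound 1 to compound 3 (0.35 log units; beyond the scatter) and so provides the first single-change comparison, with a modest step beyond the scatter. This shows that the bromo on this aromatic carbon, para to the hydroxy group, is not required for the cytotoxic effect on this read-out, and that hydrogen at this position gives an effect at smaller amounts of compound, although this rests on one pair alone. Nothing in the available data gives a reason for the step.

Going by these compounds, whether the step reflects the simple absence of a heavy atom at this position remains open, since a chlorine atom, a methoxy group or an amine on the same carbon could fall near compound 3, near compound 1, or elsewhere. Also open, on these data alone, is how the number would respond to replacing the remaining bromo of compound 3 with hydrogen, and whether the hydroxy group contributes to the effect.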